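Trifluoromethyl for Chloro on a Slowly Cleared Core

The source may report more compounds than this note shows. Statements on the series, on what has been measured and on what is new or still open speak of the compounds shown alone.

Compound 1 `Nc1n[nH]c2cc(-c3ccc(=O)n(Cc4cccc(Cl)c4)c3)ccc12` is measured in an ADME assay on microsomes (Mus musculus) for metabolic stability, read by LC-MS, using NADPH, with a stated time of 1 h, tested at 1 uM (on this read-out lower numbers stand for slow clearance and higher numbers for fast clearance), and gives < 10 mL.min-1.g-1, which is a limit of the assay rather than a number. Compound 3 `Nc1n[nH]c2cc(-c3ccc(=O)n(Cc4ccccc4F)c3)ccc12` gives < 10 mL.min-1.g-1, again a limit. The step that the two limits leave unreadable from compound 1 to compound 3 therefore cannot be read. Compound 2 `O=c1ccc(-c2ccc3cn[nH]c3c2)cn1Cc1ccccc1` differs from compound 1 in several places. In this assay compound 2 gives 157 mL.min-1.g-1. Compound 4 `Nc1n[nH]c2cc(-c3ccc(=O)n(Cc4cccc(C(F)(F)F)c4)c3)ccc12` carries trifluoromethyl in place of chloro on an aromatic carbon. Among the compounds with values here, no measured step speaks directly to this change, since the limit of < 10 mL.min-1.g-1 in this assay, at which 2 of the 3 values shown sit, hides any movement between compound 1 and compound 3. Compound 4 is therefore expected to stay at the slow end, with an estimated step of a number no lower from compound 1 to compound 4 (the limit leaves the size open) that should not exceed the scatter. The intrinsic clearance of compound 4 in this assay is estimated at 10 mL.min-1.g-1, between 4 mL.min-1.g-1 and 30 mL.min-1.g-1.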

Compound 4, intrinsic clearance in microsomes: < 10 mL.min-1.g-1
Compound 4: no number, only a limit; the forecaster's own chance of this, stated with the estimate: 55%; the middle value sits exactly at the limit.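

In this assay, within the data shown here, compound 4 gives < 10 mL.min-1.g-1 as a limit of the assay and not a number, so no step from compound 1 to compound 4 can be read: the limit of < 10 mL.min-1.g-1 in this assay, at which 3 of the 4 values shown sit. The compounds shown leave open whether trifluoromethyl and chloro differ at all in intrinsic clearance on the shared core.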